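Replacing the (3-hydroxy-1-phenylpropyl)amino group: an efficacy forecast

The source may report more compounds than this note shows. Statements on the series, on what has been measured and on what is new or still open speak of the compounds shown alone.

Of the compounds shown here, three on a shared core have been measured in a functional assay on CHO cells for activation of 5-hydroxytryptamine receptor 1D (Homo sapiens), read by GTPgammaS binding; on this read-out higher numbers stand for larger maximal responses and lower numbers for smaller maximal responses. Compound 1 `O=S(=O)(NCC1CCN(CCCc2c[nH]c3ccc(-n4cnnc4)cc23)CC1)c1ccccc1` carries a ((phenylsulfonyl)amino)methyl group on a saturated ring carbon and gives 73% in this assay. Compound 2 `COC[C@H](NC1CCN(CCCc2c[nH]c3ccc(-n4cnnc4)cc23)CC1)c1ccccc1` bears a (2-methoxy-1-phenylethyl)amino group at that position and reaches 93%. Compound 3 `OCCC(NC1CCN(CCCc2c[nH]c3ccc(-n4cnnc4)cc23)CC1)c1ccccc1` carries a (3-hydroxy-1-phenylpropyl)amino group and gives 100%, the highest of the three numbers, though its gap to compound 2 lies within the scatter. The steps of a number 20 percentage points higher from compound 1 to compound 2 (beyond the scatter) and a number 27 percentage points higher from compound 1 to compound 3 (beyond the scatter) are both beyond the scatter, whereas the step of a number 7 percentage points higher from compound 2 to compound 3 (within the scatter) is not.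

Compound 4 `c1ccc2c(c1)CCC2NCC1CCN(CCCc2c[nH]c3ccc(-n4cnnc4)cc23)CC1` differs from compound 3 in one place: ((2,3-dihydro-1H-inden-1-yl)amino)methyl in place of (3-hydroxy-1-phenylpropyl)amino on a saturated ring carbon. The entering group keeps an amine nitrogen, as in compounds 2 and 3, rather than the ((phenylsulfonyl)amino)methyl group of compound 1. For the measured compounds named here, the measured steps that bear on this are the two from compound 1, both modest and both rising; no measured step covers the loss of the hydroxyl or the entry of the 2,3-dihydro-1H-inden-1-yl ring. Compound 4 is therefore expected to give about 88% in this assay, with a range from 70% to 105%. This corresponds to an expected step of a number 12 percentage points lower from compound 3 to compound 4 (beyond the scatter), which would lie within the scatter.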

Compound 4, largest response reached (reported as efficacy), in percent of the reference or control that the assay uses: 78%
For compound 4 the middle estimate is 10 percentage points above the measured one; low and high end bracket the measured number.
By their numbers in this assay, from the lowest: compounds 1 and 4 (each within the scatter of the next); then compounds 2 and 3 (each within the scatter of the next).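

In this assay, an amine nitrogen in the entering group does not by itself keep the maximal response at this position, as the change to the ((2,3-dihydro-1H-inden-1-yl)amino)methyl group gives a number 22 percentage points lower from compound 3 to compound 4 (beyond the scatter) and a number 15 percentage points lower from compound 2 to compound 4 (beyond the scatter). Against the ((phenylsulfonyl)amino)methyl group the same change gives a number 5 percentage points higher from compound 1 to compound 4 (within the scatter), so 2,3-dihydro-1H-inden-1-yl in place of phenylsulfonyl on the amine nitrogen cannot be told apart from compound 1 in this read-out. The rise from compound 1 seen earlier therefore holds for compound 2 and compound 3, while compound 4 goes against it, and the two groups that give the larger responses both carry an oxygen, which the entering group lacks.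

No measurement to hand explains these steps. Going by these compounds, this single change removes the oxygen, closes a five-membered ring and adds a methyl link all at once, so it stays open which of these matters, and how a (benzylamino)methyl group or a hydroxyl on the 2,3-dihydro-1H-inden-1-yl ring would read here would help to separate them.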